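The source may report more compounds than this note shows. Statements on the series, on what has been measured and on what is new or still open speak of the compounds shown alone.

Of the compounds shown here, three have so far been tested in an ADME assay on HEp-2 cells (Homo sapiens) for cytotoxicity, read by MTT assay, with a stated time of 3 days; on this read-out lower numbers stand for higher toxicity in this test and higher numbers for lower toxicity in this test. Compound 1 `CC[C@@H](CCn1cncn1)c1ccc(F)cc1` gives 90.3 ug/mL, compound 2 `CCC[C@@H](CCn1cncn1)c1ccc(F)cc1` gives 55.3 ug/mL, and compound 3 `CCCC[C@@H](CCn1cncn1)c1ccc(OC)cc1` gives 31.6 ug/mL, the lowest of the three numbers, though its gap to compound 2 lies within the scatter and only its gap to compound 1 lies beyond it. Among the measured compounds shown here, the one measured step is a 1.6-fold lower number from compound 1 to compound 2 (0.21 log units; within the scatter). Compound 4 `CCCC[C@@H](CCn1cncn1)c1ccc(F)cc1` differs from compound 3 by fluoro in place of methoxy on an aromatic carbon. For the measured compounds named here, no measured step swaps these two groups, so the change is untested here; compound 4 shares the fluoro group with compound 2, and compound 2 gives 55.3 ug/mL. For compound 4 the expected step in this assay is a 1.3-fold higher number from compound 3 to compound 4 (0.10 log units; within the scatter), not beyond the scatter. Compound 4 is therefore estimated at 40 ug/mL, between 20 ug/mL and 80 ug/mL.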

Compound 4, half-maximal cytotoxic concentration: 36 ug/mL
Beside the measured number, compound 4's estimate is 1.1-fold (0.05 log units) above it, within the range that was stated.
By their numbers in this assay, from the lowest: compounds 3, 4, 2 and 1 (each within the scatter of the next, the first and the last beyond it).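

On this aromatic carbon, para to a large group, fluoro in place of methoxy gives a 1.1-fold higher number from compound 3 to compound 4 (0.06 log units; within the scatter), so in this assay this swap does not move the number beyond the scatter. Among the compounds shown here, with fluoro held fixed, adding a methyl to the chain gives a 1.5-fold lower number from compound 2 to compound 4 (0.19 log units; within the scatter), while ethyl in place of hydrogen gives a 2.5-fold lower number from compound 1 to compound 4 (0.40 log units; beyond the scatter), the only one of these steps beyond the scatter. Nothing available explains these numbers. Still open, on these data alone, is whether an amine or a carboxylic acid on this ring carbon would shift the number beyond the scatter. A longer chain might also lower it further.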